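Notes on the step from phenyl to 4-nitrophenyl

The source may report more compounds than this note shows. Statements on the series, on what has been measured and on what is new or still open speak of the compounds shown alone.

In a functional assay on MKN-45 cells (Homo sapiens) for cytotoxicity (a higher number here means a weaker inhibitor, a lower number a stronger inhibitor), compound 1 `COc1ccc(S(=O)(=O)N2CCc3cccc(NS(=O)(=O)c4ccc(F)cc4)c32)cc1` gives 890 nM and compound 2 `COc1ccc(S(=O)(=O)N2CCc3cccc(NS(=O)(=O)c4ccccc4)c32)cc1` gives 562 nM. Within the data shown here, these two values lie within the scatter of each other, so compound 2 does not stand apart from the only other measured compound. Compound 3 `COc1ccc(S(=O)(=O)N2CCc3cccc(NS(=O)(=O)c4ccc([N+](=O)[O-])cc4)c32)cc1` differs from compound 2 at one place: nitro in place of hydrogen on an aromatic carbon. This is nitro in place of hydrogen on an aromatic carbon, para to a large group. Among the measured compounds shown here, only one measured step bears on that place, hydrogen in place of fluoro, and it is a 1.6-fold lower number from compound 1 to compound 2 (0.20 log units; within the scatter). Fluoro and nitro are different groups, so this step is only a loose guide, and no change beyond the scatter is expected in this assay. The expected step is a 1.2-fold higher number from compound 2 to compound 3 (0.10 log units; within the scatter). For compound 3 the estimated value is 700 nM, with an expected range of 250 nM to 2000 nM.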

Compound 3, half-maximal inhibitory concentration: 933 nM
Compound 3: middle estimate off by 1.3-fold (0.12 log units), on the low side; the measured number falls inside the stated range.
By their numbers in this assay, from the lowest: compounds 2, 1 and 3 (each within the scatter of the next).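

Notes on the series: in this assay, nitro on the aromatic carbon para to a large group gives no step beyond the scatter, whether it replaces hydrogen (a 1.7-fold higher number from compound 2 to compound 3 (0.22 log units; within the scatter)) or fluoro (a 1.0-fold higher number from compound 1 to compound 3 (0.02 log units; within the scatter)). The earlier compounds shown here compared only hydrogen and fluoro at this position; with nitro, a group of three heavy atoms, the position still shows no separation among the three groups in this assay. No supporting data bear on the reason for this result.

Going by these compounds, whether an amine or a carboxylic acid on the same carbon would separate from these three groups remains open. On these data alone, it also remains open whether nitro on another carbon of this ring would read the same.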